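Swapping piperidine for methylpiperazine on two different cores

The source may hold more compounds than are shown below. What is called first, only, known or untested is meant among the compounds shown, and "the series" means these compounds.

Of the compounds shown here, three have been tested in a functional assay on the whole organism (strain Wister albino) for inhibition, with Rattus norvegicus as the target, read by paw edema, with stated times of 1 h and 4 h, at a dose of 50 mg/kg by the intraperitoneal route (a lower number here means less inhibition, a higher number more inhibition at the dose given (going by the name of the read-out)), and a fourth awaits its turn. Compound 1, with the structure `CCOC(=O)c1c(-c2ccc(Cl)cc2)cc(-c2ccccc2)nc1N1CCCCC1`, gives 70.1%. Compound 2, with the structure `CCOC(=O)c1c(-c2ccc(Cl)cc2)cc(-c2ccccc2)nc1N1CCN(C)CC1`, gives 37.8%. For the measured compounds named here, the only change between them is 4-methylpiperazin-1-yl in place of piperidin-1-yl on an aromatic carbon, and it produced a number 32.3 percentage points lower from compound 1 to compound 2 (beyond the scatter), a drop that stands outside the usual scatter of repeated measurements.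

Compound 3, with the structure `Cn1c([S-])n[n+]2c(N)c(C#N)c(-c3ccc(N4CCCCC4)cc3)c(C#N)c12`, gives 51.1%. Its core is quite different from that of compound 1, and the difference between the two cores is not broken down here. Compound 4, with the structure `CN1CCN(c2ccc(-c3c(C#N)c(N)[n+]4nc([S-])n(C)c4c3C#N)cc2)CC1`, is the compound still to be measured. It differs from compound 3 by 4-methylpiperazin-1-yl in place of piperidin-1-yl on an aromatic carbon. Going by the values given here, this is the same kind of change as the one from compound 1 to compound 2, but the surroundings differ: in compound 1 the group sits on a six-membered aromatic ring with 1 nitrogen, next to the ring nitrogen, ortho to an ethoxycarbonyl group, meta to a 4-chlorophenyl group and meta to a phenyl group, whereas in compound 3 it sits on a six-membered aromatic ring of carbon only, para to a large group.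

The expected step from compound 3 to compound 4 is a number 19.1 percentage points lower from compound 3 to compound 4 (beyond the scatter), placed beside the measured a number 32.3 percentage points lower from compound 1 to compound 2 (beyond the scatter). That expectation rests on a single measured pair, and because the core and the place of the change are not the same as in a number 32.3 percentage points lower from compound 1 to compound 2 (beyond the scatter), the step is expected to be smaller, with wide uncertainty. Compound 4 is therefore estimated to give 32%, expected to fall between 12% and 52%.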

Compound 4, a percentage reported as inhibition, in the whole organism at one dose (the size of the read-out at that dose, not a potency): 36.6%
For compound 4 the middle estimate is 4.6 percentage points below the measured one; measured number inside the range.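

In this assay, 4-methylpiperazin-1-yl in place of piperidin-1-yl again goes with less inhibition on this second core, with a number 14.5 percentage points lower from compound 3 to compound 4 (beyond the scatter) and so the direction of the change carries over from the core of compound 1 to the core of compound 3. The size of the step does not carry over, and the gap between the two steps is larger than repeated measurements would normally produce: the same change on two cores in this assay, a number 32.3 percentage points lower (beyond the scatter) from compound 1 to compound 2 and a number 14.5 percentage points lower (beyond the scatter) from compound 3 to compound 4, 17.8 percentage points apart, beyond the scatter of two such steps

These two pairs do not show why the steps differ in size, since the core and the place of the change both differ between them and their contributions cannot be separated. Nor do they show that the direction would hold on a third core, or how large the step would be there.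

As far as these compounds go, what remains open is whether the fall in inhibition follows from the methyl group or from the second ring nitrogen, which piperazin-1-yl without the methyl group or morpholin-4-yl at the same place could help to tell apart. From the compounds shown here alone, it also remains open whether an open-chain amine such as dimethylamino would follow piperidin-1-yl or 4-methylpiperazin-1-yl on either core.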